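This account rests on a few compounds, and the source may have more. Where it says the series, first, only, none or still open, it means among the compounds named here.

Series notes. Among the compounds with values here, compound 3 `O=C(NCCNS(=O)(=O)c1ccc(-c2ccccc2Oc2ccc([N+](=O)[O-])c([N+](=O)[O-])c2)s1)Nc1ccc(Cl)cc1` is the only member with a definite number in a functional assay on HL-60 cells (Homo sapiens) for inhibition, read by CCK-8 assay, with a stated time of 48 h (a higher number here means a weaker inhibitor, a lower number a stronger inhibitor), where compound 3 gives 8100 nM. Compound 1 `Nc1ccc(Oc2ccccc2-c2ccc(S(=O)(=O)NCCNC(=O)Nc3ccc(Cl)cc3)s2)cc1` returns in this assay only a limit, > 50000 nM. Compound 2 `COc1ccc(NC(=O)NCCNS(=O)(=O)c2ccc(-c3ccccc3Oc3ccc([N+](=O)[O-])cc3)s2)cc1` likewise returns in this assay only a limit, > 50000 nM. Within the data shown here, the single measured step, an at least 6.1-fold lower number from compound 1 to compound 3 (0.79 log units; beyond the scatter), rests on (the limit of > 50000 nM in this assay, at which 2 of the 3 values shown sit), so its true size is known only as a floor.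

Compound 4 `COc1ccc(NC(=O)NCCNS(=O)(=O)c2ccc(-c3ccccc3Oc3ccc([N+](=O)[O-])c([N+](=O)[O-])c3)s2)cc1` differs from compound 3 by methoxy in place of chloro on an aromatic carbon. Among the measured compounds shown here, no measured step covers this exchange on its own. Compound 1 carries the chloro and compound 2 the methoxy, but the two also differ in the group on the oxygen, and both sit at the limit, so nothing about the chloro-to-methoxy exchange can be read from that pair. The dinitrophenyl that separates compound 3 from the limit of compound 1 is retained in compound 4. With no evidence pointing either way, the step of a 1.5-fold higher number from compound 3 to compound 4 (0.17 log units; within the scatter) is expected to stay within the usual scatter. The range is set wide, since the two compounds at the limit leave the exchange itself unmeasured. Compound 4 is therefore estimated at 12000 nM, between 4000 nM and 50000 nM in this assay.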

Compound 4, half-maximal inhibitory concentration: 5400 nM
Compound 4: the middle estimate sits 2.2-fold (0.35 log units) above what was measured, and the stated range covers the measured number.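

In this assay, the exchange at this position gives a 1.5-fold lower number from compound 3 to compound 4 (0.18 log units; within the scatter), so with the 3,4-dinitrophenyl kept in place, the 4-chlorophenyl and 4-methoxyphenyl cannot be told apart. The step of an at least 9.2-fold lower number from compound 2 to compound 4 (0.96 log units; beyond the scatter) lies beyond the scatter and, unlike the earlier step, which replaced 4-aminophenyl with 3,4-dinitrophenyl, isolates the addition of one nitro group with the methoxy held fixed; that single change is enough to move the series from a limit to a definite number. This step starts from a limit, so its true size is known only as a floor: the limit of > 50000 nM in this assay, at which 2 of the 4 values shown sit.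

As far as these compounds go, the level reading for chloro and methoxy holds only for the pair carrying the 3,4-dinitrophenyl, and whether it extends to other groups on the oxygen remains open. Also open, from the compounds shown here alone, is how a nitrile or a carboxylic acid in place of either nitro group, or an unsubstituted phenyl in place of the 4-chlorophenyl or 4-methoxyphenyl, would read in this assay.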